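Swapping the amide's aryl group for a methylpyrazole

A few compounds are considered here, and "the series" means these few. Any claim that something is new, unique, unknown or untested is made for them only; others in the source may bear on it.

Of the compounds shown here, two have been measured in an assay on cells for inhibition of C-X-C chemokine receptor type 4 (Homo sapiens), with a stated time of 22 h, tested at 100 nM; a lower number here means less inhibition, a higher number more inhibition at the concentration tested (going by the name of the read-out). Compound 1, with the structure `O=C(NCc1ccc(CNS(=O)(=O)c2ccc3c(c2)CCO3)cc1)c1cccc2c1COC2`, gives 40% in this assay. Compound 2, with the structure `O=C(NCc1ccc(CNS(=O)(=O)c2ccc(F)cc2F)cc1)c1cncnc1`, gives 74% in this assay. Compound 1 thus stands lowest of the two numbers, with compound 2 a gap above it that lies beyond the usual scatter. Compound 2 differs from compound 1 in more than one place, so its higher number cannot be tied to any single change.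

Compound 3, with the structure `Cn1nccc1C(=O)NCc1ccc(CNS(=O)(=O)c2ccc3c(c2)CCO3)cc1`, has not yet been measured. It differs from compound 1 in one place: a group of 6 heavy atoms (4 carbon, 2 nitrogen; one five-membered aromatic ring with 2 hetero atoms) in place of a group of 9 heavy atoms (8 carbon, 1 oxygen; one five-membered non-aromatic ring with 1 hetero atom, one six-membered aromatic ring of carbon only), on a carbonyl carbon. The group that enters is the smaller of the two and carries one more hydrogen-bond acceptor than the group that leaves.

Among the measured compounds shown here, no single-change step has been measured to guide the expectation, so the step of a number 10 percentage points higher from compound 1 to compound 3 (within the scatter) is expected to be modest and of uncertain direction. Compound 3 is expected to give about 50% in this assay, within a range from 25% to 75%.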

Compound 3, a percentage reported as inhibition, at one concentration (the size of the read-out at that concentration, not a potency): 40%
The estimate for compound 3 lay 10 percentage points above the measured number; low and high end bracket the measured number.
By their numbers in this assay, from the lowest: compounds 1 and 3 (each within the scatter of the next); then compound 2.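

In this assay the 1-methyl-1H-pyrazol-5-yl group, placed on the carbonyl carbon in place of the two-ring group of compound 1, gives no change at the digits printed from compound 1 to compound 3 (within the scatter) and so adds something new: at this position the two groups cannot be told apart by this read-out. Among the compounds shown here, the entering group has fewer heavy atoms, only one ring, two nitrogens instead of an oxygen, and one more hydrogen-bond acceptor, yet none of these differences taken together moves the number beyond the scatter at the single concentration tested. No measured evidence is available to explain why these two groups read alike.

From the compounds shown here alone, the two compounds share the rest of their structure, so it remains open whether the same holds with a different group on the sulfonyl end of the molecule, and a reading at one concentration cannot show whether their potencies also match. Going by these compounds, it is also open how far this position stretches: a plain phenyl ring, a small methyl group or a carboxylic acid on the carbonyl carbon could show whether any group here changes the number.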